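A few compounds are considered here, and "the series" means these few. Any claim that something is new, unique, unknown or untested is made for them only; others in the source may bear on it.

Working notes on a chalcone series built on a common core. Compound 1 `COc1ccc(C(=O)/C=C/c2cccc(F)c2)c2c1C=CC(C)(C)O2`, compound 2 `COc1ccc(C(=O)/C=C/c2ccc(-c3ccccc3)cc2)c2c1C=CC(C)(C)O2` and compound 3 `COc1ccc(C(=O)/C=C/c2ccc(N(c3ccccc3)c3ccccc3)cc2)c2c1C=CC(C)(C)O2` have been run in a functional assay on HCT-116 cells (Homo sapiens) for antiproliferative activity, read by MTT assay, with a stated time of 24 h; a lower number here means a stronger inhibitor, a higher number a weaker inhibitor. In this assay compound 1 returns only a limit, > 10000 nM. For compound 2 the result in this assay is likewise a limit, > 10000 nM. Compound 3 in this assay also gives a limit, > 10000 nM. Compound 2 therefore stands nowhere on a numerical scale: its value is a limit, as are the two others shown, so that all three sit together at the limit of > 10000 nM in this assay, at which 3 of the 3 values shown sit, and no step between measured compounds can be stated.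

Compound 4 `COc1ccc(C(=O)/C=C/c2ccc(-n3ccnc3)cc2)c2c1C=CC(C)(C)O2` is the next member and differs from compound 2 in one place: 1H-imidazol-1-yl in place of phenyl on an aromatic carbon. With every measured value a limit, no direction or size of step in this assay is supported by the data. The expected step from compound 2 to compound 4 is estimated at a step that the limit leaves unreadable from compound 2 to compound 4, meaning no change beyond the scatter. Compound 4 is expected to give about 15000 nM in this assay, within a range of 3000 nM to 60000 nM, most likely reported again only as a limit.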

Compound 4, half-maximal inhibitory concentration: > 10000 nM
Compound 4: only a limit was reported; the forecaster's own chance of this, stated with the estimate: 80%; the middle value does not contradict the limit.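

Among the compounds shown here, compound 4 gives only a limit in this assay, as compound 2 does, so no step between compound 2 and compound 4 can be read: the limit of > 10000 nM in this assay, at which 4 of the 4 values shown sit. The compounds shown leave open which structural change, if any, would give a numerical value in this assay.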